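From a Piperazine to a Fused Bicyclic Amine

A few compounds are considered here, and "the series" means these few. Any claim that something is new, unique, unknown or untested is made for them only; others in the source may bear on it.

Compound 1 `Cn1ccc2cc(-c3ccc4oc(Nc5ccccc5)nc4c3)ccc21` carries an anilino group on its shared core. In an assay on HEK293 cells for inhibition of Fatty-acid amide hydrolase 1 (Homo sapiens), read by fluorescence (a higher number here means a weaker inhibitor, a lower number a stronger inhibitor), compound 1 gives 48 nM. Compound 2 `Cn1ccc2cc(-c3ccc4oc(N5CCNCC5)nc4c3)ccc21` has a piperazin-1-yl group in the same place. In this assay compound 2 gives > 1000 nM, which is a limit of the measurement and not a number. The step of an at least 20-fold higher number from compound 1 to compound 2 (1.31 log units; beyond the scatter) is therefore large, and compound 2 stands at the weak end of the two values shown, sitting at the limit of > 1000 nM in this assay, at which 1 of the 2 values shown sits.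

Compound 3 `Cn1ccc2cc(-c3ccc4oc(N5Cc6cccnc6C5)nc4c3)ccc21` differs from compound 2 by a group of 9 heavy atoms (7 carbon, 2 nitrogen; one five-membered non-aromatic ring with 1 hetero atom, one six-membered aromatic ring with 1 hetero atom) in place of a group of 6 heavy atoms (4 carbon, 2 nitrogen; one six-membered non-aromatic ring with 2 hetero atoms), on an aromatic carbon. The entering group is still a saturated ring bound through its nitrogen, as in compound 2, but it also brings an aromatic ring, as the anilino of compound 1 does, while it loses the hydrogen-bond donor of the piperazine. Within the data shown here, the only measured step at this position is an at least 20-fold higher number from compound 1 to compound 2 (1.31 log units; beyond the scatter). Given that large loss when an aromatic group gave way to a saturated amine, and the partial return of an aromatic ring here, compound 3 is expected to gain somewhat over compound 2, by an at least 1.6-fold lower number from compound 2 to compound 3 (0.22 log units; that floor lies within the scatter), without reaching compound 1. The estimate for compound 3 is 600 nM, expected to lie between 150 nM and 3000 nM.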

Compound 3, half-maximal inhibitory concentration: 211 nM
The estimate for compound 3 lay 2.8-fold (0.45 log units) above the measured number; the measured number falls inside the stated range.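

In this assay there is an at least 4.7-fold lower number from compound 2 to compound 3 (0.67 log units; beyond the scatter), so at this position a group bound through a ring nitrogen is not necessarily as weak as the piperazin-1-yl group of compound 2. There is also a 4.4-fold higher number from compound 1 to compound 3 (0.64 log units; beyond the scatter), so the group entering in compound 3, which brings a six-membered aromatic ring, closes part of the gap back to the anilino group of compound 1 but not all of it. The first of these steps gives only a floor for the gain, because the value for compound 2 is a limit of the measurement and not a number: the limit of > 1000 nM in this assay, at which 1 of the 3 values shown sits.

Compound 3 differs from compound 2 in several ways at once: the ring size, the added aromatic ring and the loss of the hydrogen-bond donor all change together, so the compounds shown cannot say which of these goes with the gain. A pyrrolidin-1-yl group, which has a five-membered non-aromatic ring and no aromatic ring, and a 4-methylpiperazin-1-yl group, which keeps the six-membered ring without the donor, would each separate one of these changes from the others.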